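The source may hold more compounds than are shown below. What is called first, only, known or untested is meant among the compounds shown, and "the series" means these compounds.

Measured compounds in an ADME assay for permeability, using PAMPA, with a stated time of 30 min, at pH 7.4; a higher number here means that the compound crosses the layer faster, a lower number that the compound crosses the layer more slowly:
- compound 1 `COc1ccc(F)cc1CNCCCNc1ccnc2cc(Oc3ccc(C(C)(C)C)cc3)ccc12`: 317 10^-6 cm/s
- compound 2 `COc1ccc(F)cc1CNCCCNc1ccnc2cc(Oc3ccccc3)ccc12`: 317 10^-6 cm/s

In this assay, among the compounds with values here, compound 1 gives 317 10^-6 cm/s and compound 2 gives 317 10^-6 cm/s; the single measured step, no change at the digits printed from compound 1 to compound 2 (within the scatter), leaves the read-out where it was. Compound 2 therefore stands level with compound 1 at the digits shown, with no change beyond the scatter between the two.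

Compound 3 `COc1ccc(F)cc1CNCCCNc1ccnc2cc(Oc3ccccc3OC)ccc12` is the next member. It differs from compound 2 by methoxy in place of hydrogen on an aromatic carbon, placed on an aromatic carbon of a six-membered aromatic ring of carbon only, ortho to a large group; read one bond further out, the change is phenoxy to 2-methoxyphenoxy. Within the data shown here, no measured step adds a methoxy group, so nothing bears on it directly. Among the measured compounds shown here, the only step available, the loss of tert-butyl between compound 1 and compound 2, altered this assay by nothing beyond the scatter, and a small substituent swap on the same ring is expected to behave alike: the step of a 1.1-fold lower number from compound 2 to compound 3 (0.02 log units; within the scatter) is estimated as none beyond the scatter. Compound 3 is expected to give about 300 10^-6 cm/s, in the range 150 10^-6 cm/s to 600 10^-6 cm/s.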

Compound 3, apparent permeability: 317 10^-6 cm/s
Compound 3: the middle estimate sits 1.1-fold (0.02 log units) below what was measured; the range from low to high includes it.
By their numbers in this assay, from the lowest: compounds 1, 2 and 3 (each within the scatter of the next).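

In this assay, methoxy in place of hydrogen on an aromatic carbon, ortho to a large group, gives no change at the digits printed from compound 2 to compound 3 (within the scatter) and extends the earlier tert-butyl comparison to a substituent at a different place on the same ring, one that brings in an oxygen. The direct exchange of 4-(tert-butyl)phenyl for 2-methoxyphenyl on the oxygen gives no change at the digits printed from compound 1 to compound 3 (within the scatter) and shows that the two substituted rings also read alike, so hydrogen, tert-butyl and methoxy are not separated on this read-out within these three compounds. Nothing available gives a reason for this flat result.

A carboxylic acid, an amine such as dimethylamino or a longer chain such as butoxy on this ring could still behave differently, and the present compounds do not show whether the flat read-out would hold for any of them. From the compounds shown here alone, all three compounds also share the rest of their structure, so the effect of changes elsewhere, such as an amide in place of the secondary amine in the linking chain, remains open.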